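Replacing the Isopropylpiperazine: A Stability Estimate for Compound 4

A few compounds are considered here, and "the series" means these few. Any claim that something is new, unique, unknown or untested is made for them only; others in the source may bear on it.

Values in an ADME assay (liver, Mus musculus) for metabolic stability, using microsomes; on this read-out higher numbers stand for a longer-lived compound and lower numbers for a shorter-lived compound:
- Compound 1 `CCc1nc2cc(Cl)ccn2c1C(=O)NCc1ccc(-c2ccc[nH]2)cc1` gives 0.18 h
- Compound 2 `CCc1nc2cc(Cl)ccn2c1C(=O)NCc1ccc(N2CCCCCC2)cc1` gives 0.0317 h
- Compound 3 `CCc1nc2cc(Cl)ccn2c1C(=O)NCc1ccc(N2CCN(C(C)C)CC2)cc1` gives 0.148 h

Compound 3 at 0.148 h stands with compound 1 at the upper end of these numbers, the step being a 1.2-fold lower number from compound 1 to compound 3 (0.09 log units; within the scatter). Compound 2 lies apart, with a 4.7-fold higher number from compound 2 to compound 3 (0.67 log units; beyond the scatter).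

Compound 4 `CCc1nc2cc(Cl)ccn2c1C(=O)NCc1ccc(-n2cc3c(c2)CCCC3)cc1` has not yet been measured. Its structural change is a group of 9 heavy atoms (8 carbon, 1 nitrogen; one five-membered aromatic ring with 1 hetero atom, one six-membered non-aromatic ring of carbon only) in place of a group of 9 heavy atoms (7 carbon, 2 nitrogen; one six-membered non-aromatic ring with 2 hetero atoms), on an aromatic carbon, on an aromatic carbon of a six-membered aromatic ring of carbon only, para to a large group. For the measured compounds named here, no measured step makes this exact exchange, so the evidence comes from the other exchanges at that place. The entering group holds a five-membered aromatic ring with 1 hetero atom, and the 1H-pyrrol-2-yl of compound 1 is also such a ring, which points to little change given a 1.2-fold lower number from compound 1 to compound 3 (0.09 log units; within the scatter). The azepan-1-yl of compound 2 points the other way, given a 5.7-fold lower number from compound 1 to compound 2 (0.75 log units; beyond the scatter). The two precedents disagree, and the expectation falls between them. A modest fall in this assay is expected, with the estimated step being a 2.1-fold lower number from compound 3 to compound 4 (0.33 log units; beyond the scatter). Compound 4 is estimated at 0.07 h, with an expected range from 0.025 h to 0.2 h.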

Compound 4, half-life: 1.04 h
Estimate against measurement, compound 4: 15-fold (1.17 log units) below, and the stated range ends below it.
By their numbers in this assay, from the lowest: compound 2; then compounds 3 and 1 (each within the scatter of the next); then compound 4.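

At this place, on an aromatic carbon para to a large group, the exchange of the 4-isopropylpiperazin-1-yl for the new group gives a 7.0-fold higher number from compound 3 to compound 4 (0.85 log units; beyond the scatter) in this assay. This carries the series beyond the level that compound 1 and compound 3 had shared. The same group also gives a 5.8-fold higher number from compound 1 to compound 4 (0.76 log units; beyond the scatter) and a 33-fold higher number from compound 2 to compound 4 (1.52 log units; beyond the scatter) on this read-out, which shows that this position can hold a clearly longer-lived compound than the three earlier groups suggested, and that a five-membered aromatic ring with 1 hetero atom does not by itself fix the outcome, as compound 1 carries such a ring too. No measurement presented here bears on why the half-life rises with this group.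

The compounds shown leave open whether the gain belongs to the six-membered non-aromatic ring of carbon only or to the attachment of the five-membered ring through its nitrogen, since the 1H-pyrrol-2-yl of compound 1 is attached through carbon. A plain pyrrol-1-yl group at the same place would separate these two readings, and an indol-1-yl group would show whether the second ring must be non-aromatic.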